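The compounds below may be only part of what the source reports. "The series", "measured", "known", "first", "only" and "open" are said of these compounds alone.

Compound 1 `Oc1ccc(-c2cc(-c3cccc(Cl)c3)nc(-c3ccccn3)c2)cc1` gives the highest of the two numbers recorded so far in a functional assay on DU-145 cells (Homo sapiens) for cytotoxicity, read by CCK-8 assay and cell counting, with a stated time of 2 days (on this read-out lower numbers stand for stronger inhibition and higher numbers for weaker inhibition), namely 35200 nM. Its nearest neighbour, compound 2 `Oc1ccc(-c2cc(-c3cccc(Cl)c3)nc(-c3cccs3)c2)cc1`, shows 5740 nM, and the step of a 6.1-fold lower number from compound 1 to compound 2 (0.79 log units; beyond the scatter) concerns a different structural change. Compound 3 `Oc1ccc(-c2cc(-c3ccc(Cl)cc3)nc(-c3ccccn3)c2)cc1` differs from compound 1 by 4-chlorophenyl in place of 3-chlorophenyl on an aromatic carbon. Among the measured compounds shown here, no measured step touches this particular change, so its direction is open and no step beyond the scatter in this assay is assumed. Compound 3 is therefore expected to give about 33000 nM, within a range from 8000 nM to 130000 nM, corresponding to an estimated step of a 1.1-fold lower number from compound 1 to compound 3 (0.03 log units; within the scatter).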

Compound 3, half-maximal inhibitory concentration: 22500 nM
For compound 3 the middle estimate is 1.5-fold (0.17 log units) above the measured one; the range from low to high includes it.
By their numbers in this assay, from the lowest: compound 2; then compounds 3 and 1 (each within the scatter of the next).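

Replacing 3-chlorophenyl with 4-chlorophenyl, on the carbon next to the ring nitrogen, gives a 1.6-fold lower number from compound 1 to compound 3 (0.19 log units; within the scatter) in this assay. Compounds 1 and 3 have the same atoms, joined differently, and this change of chlorine position cannot be separated from the usual scatter while pyridin-2-yl stays in place. Nothing available explains this result.

Still open, from the compounds shown here alone, is whether 2-chlorophenyl, or an amine or a carboxylic acid in place of the chlorine, would shift the number. Going by these compounds, it is also open whether the same swap behaves alike when thiophen-2-yl replaces pyridin-2-yl.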